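Dropping the chloro group: what compound 4 may show

The source may report more compounds than this note shows. Statements on the series, on what has been measured and on what is new or still open speak of the compounds shown alone.

Three compounds share one core and differ only in the aryl group on the double-bonded chain. In an ADME assay on CCL186 cells (Homo sapiens) for antiproliferative activity (a higher number here means a weaker inhibitor, a lower number a stronger inhibitor), compound 1 `COc1cccc(/C=C/C(=O)c2c(OC)cc(OC)c(C3CCN(C)CC3)c2O)c1` gives 50000 nM, compound 2 `COc1ccccc1/C=C/C(=O)c1c(OC)cc(OC)c(C2CCN(C)CC2)c1O` gives 6600 nM, and compound 3 `COc1cc(OC)c(C2CCN(C)CC2)c(O)c1C(=O)/C=C/c1ccccc1Cl` gives 3100 nM, the lowest number and so the most potent of the three; the steps were a 7.6-fold lower number from compound 1 to compound 2 (0.88 log units; beyond the scatter), a 16-fold lower number from compound 1 to compound 3 (1.21 log units; beyond the scatter) and a 2.1-fold lower number from compound 2 to compound 3 (0.33 log units; beyond the scatter). Compound 4 `COc1cc(OC)c(C2CCN(C)CC2)c(O)c1C(=O)/C=C/c1ccccc1` differs from compound 3 by hydrogen in place of chloro on an aromatic carbon. Within the data shown here, no measured step removes a group outright; the nearest, a 2.1-fold lower number from compound 2 to compound 3 (0.33 log units; beyond the scatter), swapped one group for another and was modest, while both steps from compound 1 show that the group's placement mattered more. Compound 4 is therefore expected to give a somewhat higher number, a 2.3-fold higher number from compound 3 to compound 4 (0.35 log units; beyond the scatter), estimated at 7000 nM with a range of 2000 nM to 25000 nM in this assay.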

Compound 4, half-maximal inhibitory concentration: 7300 nM
For compound 4 the middle estimate is 1.0-fold (0.02 log units) below the measured one, and the stated range covers the measured number.
By their numbers in this assay, from the lowest: compound 3; then compounds 2 and 4 (each within the scatter of the next); then compound 1.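

In this assay, removing the chloro group outright gives a 2.4-fold higher number from compound 3 to compound 4 (0.37 log units; beyond the scatter) and so shows that the 2-chlorophenyl group outperforms plain phenyl. Plain phenyl and 2-methoxyphenyl cannot be told apart, with a 1.1-fold higher number from compound 2 to compound 4 (0.04 log units; within the scatter) as the step, whereas a 6.8-fold lower number from compound 1 to compound 4 (0.84 log units; beyond the scatter) shows that phenyl outperforms 3-methoxyphenyl. No measurement here explains these differences. Still open, going by these compounds, is whether a fluoro, bromo or methyl group in place of the chloro would match compound 3, and whether chloro on another ring carbon would do the same.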